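Replacing the piperidin-4-yl group of compound 1

The compounds below may be only part of what the source reports. "The series", "measured", "known", "first", "only" and "open" are said of these compounds alone.

Compound 1 `COc1ccc(-c2noc(C3CCNCC3)n2)cc1OC1CCCC1` gives 10 nM in a functional assay on LNCaP cells (Homo sapiens) for antiproliferative activity, read by MTT assay, with a stated time of 24 h (on this read-out higher numbers stand for weaker inhibition and lower numbers for stronger inhibition), and holds the lowest number seen so far. Compound 2 `Fc1ccc(-c2nc(-c3ccccc3)no2)cc1` gives 23700 nM in this assay and is the nearest number, yet the gap to compound 1 lies well beyond the scatter of repeat measurements. For compound 3 `COc1cc(-c2noc(-c3ccncc3)n2)ccc1OCc1ccccc1` the reading of > 1000000 nM is a limit of this assay and not a number.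

Compound 4 `COc1ccc(-c2noc(-c3ccc(O)cc3)n2)cc1OC1CCCC1` keeps the rest of compound 1 but has 4-hydroxyphenyl in place of piperidin-4-yl on an aromatic carbon. Within the data shown here, no measured pair shows this change alone, so any forecast is a judgement. Compound 2 carries an aromatic ring at that carbon and gives 23700 nM in this comparison, while compound 1 has piperidin-4-yl there and gives 10 nM as its reading. Compound 3 has an aromatic ring there too, and neither compound goes against this trend, though both also differ elsewhere. A large rise beyond the scatter is therefore expected, estimated as a 400-fold higher number from compound 1 to compound 4 (2.60 log units; beyond the scatter) in this assay. For compound 4 the expected value is 4000 nM with an estimated range from 300 nM to 60000 nM in this assay.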

Compound 4, half-maximal inhibitory concentration: 860 nM
Beside the measured number, compound 4's estimate is 4.7-fold (0.67 log units) above it; the range from low to high includes it.
By their numbers in this assay, from the lowest: compound 1; then compound 4; then compound 2. At a limit, above all of these: compound 3.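

Among these compounds, this is the first pair that differs in one place only, so the change can be read directly. In this assay putting 4-hydroxyphenyl in place of piperidin-4-yl brings an 86-fold higher number from compound 1 to compound 4 (1.93 log units; beyond the scatter) and shows that the reading depends strongly on the group at this carbon of the shared core. The two groups count the same hydrogen-bond donors and acceptors and neither has a net charge, so those counts alone do not set the reading here, and compound 4 still gives 860 nM as a true number with an aromatic ring at this carbon.

This single pair cannot separate losing the ring nitrogen from moving to an aromatic ring, and cyclohexyl, a ring of carbon only that is not aromatic, or 4-aminophenyl, an aromatic ring that carries an amine, would speak to that question. Compound 3 adds no step to this comparison, as its reading is a limit and not a number: the limit of > 1000000 nM in this assay, at which 1 of the 4 values shown sits.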